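This account rests on a few compounds, and the source may have more. Where it says the series, first, only, none or still open, it means among the compounds named here.

In a functional assay on QG-56 cells (Homo sapiens) for antiproliferative activity (a higher number here means a weaker inhibitor, a lower number a stronger inhibitor), compound 1 `COc1ccc(C(O)(c2cc3cc([N+](=O)[O-])cc(-c4ccccc4)c3o2)c2cncn2C)cc1` gives 4970 nM, compound 2 `Cn1cncc1C(O)(c1ccc(C#N)cc1)c1cc2cc([N+](=O)[O-])cc(-c3ccc(C#N)cc3)c2o1` gives 32.6 nM, and compound 3 `Cn1cncc1[C@@](N)(c1ccc(C#N)cc1)c1cc2cc(C#N)cc(-c3cccc(C#N)c3)c2o1` gives 2 nM. Compound 2 thus holds the second highest of the three numbers, and its gaps to the other two lie beyond the scatter. Compound 4 `Cn1cncc1C(O)(c1ccc(C#N)cc1)c1cc2cc([N+](=O)[O-])cc(-c3cccc(C#N)c3)c2o1` differs from compound 2 in one place, with 3-cyanophenyl in place of 4-cyanophenyl on an aromatic carbon. Among the compounds with values here, no measured pair shows this swap alone. Compound 3, at 2 nM, carries the 3-cyanophenyl group but also differs from compound 2 elsewhere, so it offers only a weak hint towards a lower number. The expected step, a 1.5-fold lower number from compound 2 to compound 4 (0.17 log units; within the scatter), stays within the scatter. For compound 4 the estimated value is 22 nM, within an expected range of 7 nM to 70 nM.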

Compound 4, half-maximal inhibitory concentration: 22.9 nM
Compound 4: the middle estimate sits 1.0-fold (0.02 log units) below what was measured; measured number inside the range.
By their numbers in this assay, from the lowest: compound 3; then compounds 4 and 2 (each within the scatter of the next); then compound 1.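

In this assay, putting 3-cyanophenyl in place of 4-cyanophenyl, on an aromatic carbon meta to a nitro group, gives a step that stays within the usual scatter (a 1.4-fold lower number from compound 2 to compound 4 (0.15 log units; within the scatter)). Within the data shown here, this is the first pair that differs in this one place alone, and it shows that the two groups read alike at this position. From the compounds shown here alone, whether 2-cyanophenyl, or a phenyl ring carrying an amine or a carboxylic acid, would also read alike here stays open. Nothing available explains why these two groups give such similar numbers.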